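A few compounds are considered here, and "the series" means these few. Any claim that something is new, unique, unknown or untested is made for them only; others in the source may bear on it.

Measured compounds:
Compound 1 `Cc1noc(C)c1-c1cnc(N)c(Oc2ccc(C(=O)NC3CC3)cc2)n1`: in a functional assay on LoVo cells (Homo sapiens) for inhibition, read by MTT assay, with a stated time of 72 h (on this read-out lower numbers stand for stronger inhibition and higher numbers for weaker inhibition), compound 1 gives > 100000 nM, which is a limit of the assay and not a number.
Compound 2 `Cc1noc(C)c1-c1cnc(N)c(Oc2ccc(C(=O)Nc3cccc(Cl)c3)cc2)n1`: in this assay compound 2 gives 1640 nM.
Compound 3 `Cc1noc(C)c1-c1cnc(N)c(Oc2ccc(C(=O)Nc3cccc(Cl)n3)cc2)n1`: in this assay compound 3 gives 39300 nM.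

Among the measured compounds shown here, compound 1 therefore stands nowhere on a real scale: only a limit is known for it, and it is the one compound sitting at the limit of > 100000 nM in this assay, at which 1 of the 3 values shown sits. All three share the same core and differ only in the group carried on the amide-type nitrogen.

Compound 4 `Cc1noc(C)c1-c1cnc(N)c(Oc2ccc(C(=O)Nc3ccc(Cl)cn3)cc2)n1` takes the step (5-chloropyridin-2-yl in place of cyclopropyl on an amide-type nitrogen). Two measured steps start from the same cyclopropyl amide: an at least 60-fold lower number from compound 1 to compound 2 (1.78 log units; beyond the scatter) and an at least 2.5-fold lower number from compound 1 to compound 3 (0.40 log units; beyond the scatter). Both replacements by a chlorinated aromatic ring gave a lower number than the limit of compound 1, but by very different amounts, as a 24-fold higher number from compound 2 to compound 3 (1.38 log units; beyond the scatter) shows for the change from the chlorophenyl to the chloropyridinyl ring. The 5-chloropyridin-2-yl of compound 4 is a pyridine ring like that of compound 3, with the chlorine in another spot, so a clearly lower number than the limit of compound 1 is expected, most likely landing between compounds 2 and 3; the expected step is an at least 10-fold lower number from compound 1 to compound 4 (1.00 log units; beyond the scatter). Compound 4 is estimated at 10000 nM, with a range from 2000 nM to 60000 nM.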

Compound 4, half-maximal inhibitory concentration: 9180 nM
The estimate for compound 4 lay 1.1-fold (0.04 log units) above the measured number; measured number inside the range.
By their numbers in this assay, from the lowest: compound 2; then compound 4; then compound 3. At a limit, above all of these: compound 1.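

Among the two pyridine rings, which differ only in where the chlorine sits, the place of the chlorine changes the result in this assay: there is a 4.3-fold lower number from compound 3 to compound 4 (0.63 log units; beyond the scatter), so the ring nitrogen does not by itself set the number. Even so, the 5-chloropyridin-2-yl group does not match the 3-chlorophenyl group, with a 5.6-fold higher number from compound 2 to compound 4 (0.75 log units; beyond the scatter), and both pyridine compounds, compound 3 and compound 4, give higher numbers than compound 2. Against the cyclopropyl amide there is an at least 10-fold lower number from compound 1 to compound 4 (1.03 log units; beyond the scatter), but that size is only a bound, since compound 1 is held at a limit of the assay and not a number: the limit of > 100000 nM in this assay, at which 1 of the 4 values shown sits.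

As far as these compounds go, it remains open whether the chlorine is needed at all, and what a plain phenyl or pyridin-2-yl ring, or a methoxy group or nitrile in place of the chlorine, would give on the amide-type nitrogen. The four compounds also share one core and one read-out, so they give no reason for these differences and do not show whether the same order would hold on another core.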